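This account rests on a few compounds, and the source may have more. Where it says the series, first, only, none or still open, it means among the compounds named here.

Measured so far:

Compound 1, `COc1ccc(-c2cc(/C=C/C(=O)c3ccc(OC)c(OC)c3)[nH]n2)cc1`: in a functional assay on BT-549 cells (Homo sapiens) for inhibition, read by sulforhodamine B assay, with a stated time of 48 h (a higher number here means a weaker inhibitor of growth, a lower number a stronger inhibitor of growth), compound 1 gives 1680 nM.
Compound 2, `COc1cc(-c2cc(/C=C/C(=O)c3ccc(Cl)c(Cl)c3)[nH]n2)cc(OC)c1OC`: in this assay compound 2 gives 8400 nM.
Compound 3, `COc1ccc(-c2cc(/C=C/C(=O)c3cc(OC)c(OC)c(OC)c3)[nH]n2)cc1OC`: in this assay compound 3 gives 1360 nM.

Compound 2 stands highest of the three numbers in this assay. Compound 1 lies nearest to it and compound 3 furthest, and both of those gaps fall beyond the usual scatter. The two lower numbers belong to compounds that carry methoxy-bearing phenyl groups on the carbonyl carbon, whereas compound 2 carries the 3,4-dichlorophenyl there; with three compounds this is an observation only, not a pattern.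

Compound 4, `COc1cc(-c2cc(/C=C/C(=O)c3ccc(F)c(F)c3)[nH]n2)cc(OC)c1OC`, has not yet been measured in this assay. It differs from compound 2 in one place: 3,4-difluorophenyl in place of 3,4-dichlorophenyl on a carbonyl carbon. The heavy-atom count, the donor and acceptor counts and the charge are unchanged; only the two halogens on that ring are exchanged.

Among the measured compounds shown here, no measured pair shows a halogen-for-halogen exchange on the aryl attached to the carbonyl carbon, so the step has no direct support in the numbers. A small step, if any, toward a lower number is expected, close to the scatter; the expected step from compound 2 to compound 4 is a 1.4-fold lower number from compound 2 to compound 4 (0.15 log units; within the scatter). Compound 4 is estimated at 6000 nM in this assay, with a range from 2500 nM to 15000 nM.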

Compound 4, concentration for 50% growth inhibition: 4110 nM
Compound 4: the middle estimate sits 1.5-fold (0.16 log units) above what was measured, within the range that was stated.
By their numbers in this assay, from the lowest: compounds 3 and 1 (each within the scatter of the next); then compound 4; then compound 2.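

In this assay, among the compounds shown here, 3,4-difluorophenyl in place of 3,4-dichlorophenyl on the carbonyl carbon gives a 2.0-fold lower number from compound 2 to compound 4 (0.31 log units; beyond the scatter), the first step in which only one place differs. The step is modest, but it shows that the read-out responds to the identity of the two halogens on this ring, even though the heavy-atom count, the donor and acceptor counts and the charge stay the same. No measurement shown here bears on the reason for this difference, so the step stands as an observation only.

Still open, going by these compounds, is how far this position tolerates other groups on the same ring, such as two bromine atoms, an unsubstituted phenyl, an amine or a carboxylic acid, and whether the order of fluorine and chlorine would hold across those further halogen or non-halogen variants. For the compounds shown here, also open is whether the same exchange gives a step of similar size when the aryl group at the other end of the shared core is something other than the one in compound 2 and compound 4.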